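The source may hold more compounds than are shown below. What is called first, only, known or untested is meant among the compounds shown, and "the series" means these compounds.

Working notes, series of analogues sharing one core. Compound 1 `COc1cc(-c2nn(-c3cccc(NC(=O)Nc4cccc(C(F)(F)F)c4)c3)cc2-c2ccncc2)ccc1Cl` carries a urea; in a functional assay on COLO 205 cells (Homo sapiens) for inhibition, read by sulforhodamine B assay, with a stated time of 48 h (on this read-out higher numbers stand for weaker inhibition of growth and lower numbers for stronger inhibition of growth), compound 1 gives 894 nM. Compound 2 `COc1cc(-c2nn(-c3cccc(NC(=O)c4ccc(Cl)c(C(F)(F)F)c4)c3)cc2-c2ccncc2)ccc1Cl` replaces that urea with a benzamide, and in this assay compound 2 gives 6140 nM. Among the compounds with values here, the one measured step, a 6.9-fold higher number from compound 1 to compound 2 (0.84 log units; beyond the scatter), is modest but beyond the scatter, and compound 2 holds the highest of the two numbers so far.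

Compound 3 `COc1cc(-c2nn(-c3cccc(NC(=O)c4ccccc4)c3)cc2-c2ccncc2)ccc1Cl` differs from compound 2 only by phenyl in place of 4-chloro-3-(trifluoromethyl)phenyl on a carbonyl carbon. Within the data shown here, no measured step covers this change: the step from compound 1 to compound 2 concerns the linker, not the substitution of the aryl ring, so nothing in hand tells the direction. On the two numbers available, compound 3 is expected to sit near compound 2, with the step of a 1.5-fold higher number from compound 2 to compound 3 (0.17 log units; within the scatter) estimated to be small or within the scatter. Compound 3 is therefore estimated at 9000 nM in this assay, with a range of 3000 nM to 30000 nM.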

Compound 3, concentration for 50% growth inhibition: 522 nM
For compound 3 the middle estimate is 17-fold (1.24 log units) above the measured one, outside the stated range (below it).
By their numbers in this assay, from the lowest: compounds 3 and 1 (each within the scatter of the next); then compound 2.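

On the carbonyl carbon of the benzamide, the aryl substitution matters: in this assay there is a 12-fold lower number from compound 2 to compound 3 (1.07 log units; beyond the scatter) when phenyl replaces 4-chloro-3-(trifluoromethyl)phenyl. The amide linkage alone therefore does not set the high number of compound 2, since the plain benzamide compares with the urea as a 1.7-fold lower number from compound 1 to compound 3 (0.23 log units; within the scatter) and the two cannot be told apart. The step from compound 1 to compound 2 thus cannot be read as a simple urea-to-amide effect. No measurement on hand bears on the reason for the large step to phenyl.

The compounds shown leave open whether the chloro or the trifluoromethyl group alone accounts for the step, since neither appears singly on the benzamide ring. They also leave open how a methoxy group or an amine on that phenyl ring would read.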